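Chalcone piperazines: sulfonyl in place of nitrophenyl

The source may hold more compounds than are shown below. What is called first, only, known or untested is meant among the compounds shown, and "the series" means these compounds.

Measured so far:
compound 1, `O=C(/C=C/c1ccccc1)c1ccc(N2CCN(c3ccc([N+](=O)[O-])cc3)CC2)cc1`, 55.4%
compound 2, `O=C(/C=C/c1ccc(Cl)cc1)c1ccc(N2CCN(S(=O)(=O)c3ccc(C(F)(F)F)cc3)CC2)cc1`, 59.6%

Two compounds of this series carry a number in a functional assay on the whole organism (strain Kunming) for inhibition, with Mus musculus as the target, with a stated time of 1 h, at a dose of 40 mg/kg by the oral route; on this read-out higher numbers stand for more inhibition at the one dose given (going by the name of the read-out) and lower numbers for less inhibition. Compound 1 gives 55.4% and compound 2 gives 59.6%. The gap between them lies within the scatter of repeated measurements, so compound 1 stands alongside compound 2 and neither can be set above the other on these two numbers. Among the compounds with values here, the two differ in more than one place, so no single step can be drawn between them.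

Compound 3, `O=C(/C=C/c1ccccc1)c1ccc(N2CCN(S(=O)(=O)c3ccccc3)CC2)cc1`, is not yet measured. It differs from compound 1 in one place: phenylsulfonyl in place of 4-nitrophenyl on an amine nitrogen in a ring. Compound 2 also carries a sulfonyl on the ring nitrogen, yet it is not a single-change partner of compound 1, so what this exchange alone does is not shown anywhere in the data. Within the data shown here, with only one pair in hand and that pair within the scatter, no step beyond the scatter is expected in either direction from compound 1 to compound 3, a number 1.6 percentage points higher from compound 1 to compound 3 (within the scatter). For compound 3 the expected value in this assay is 57%, with a range of 40% to 72%.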

Compound 3, a percentage reported as inhibition, in the whole organism at one dose (the size of the read-out at that dose, not a potency): 30%
The estimate for compound 3 lay 27 percentage points above the measured number, outside the stated range (below it).
By their numbers in this assay, from the lowest: compound 3; then compounds 1 and 2 (each within the scatter of the next).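

In this assay, within the data shown here, the exchange of 4-nitrophenyl for phenylsulfonyl on an amine nitrogen in a ring gives a number 25.4 percentage points lower from compound 1 to compound 3 (beyond the scatter), the first single-change step, and it shows that the read-out at this dose depends on what this nitrogen carries. A sulfonyl here is not tied to one level of inhibition by these data alone: compound 2 also has a sulfonyl on this nitrogen, but it differs from compound 3 in more than one place, so the two cannot be read as a pair. Nothing available explains the size or direction of this step.

The compounds shown leave open whether the step follows from the sulfonyl link or from the absence of the nitro group, which a plain phenyl or a nitro-bearing phenylsulfonyl on the same nitrogen would separate. Also open, going by these compounds, is what a trifluoromethyl on the phenylsulfonyl ring of compound 3, or a chlorine on its other phenyl ring, would do when introduced alone.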